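The source may report more compounds than this note shows. Statements on the series, on what has been measured and on what is new or still open speak of the compounds shown alone.

Compound 1 `Cc1cccc(S(=O)(=O)N2CCC(N3CCC(C)CC3)CC2)c1` stands highest of the three numbers in a functional assay on DLD-1 cells (Homo sapiens) for antiproliferative activity, read by CellTiter-Glo, with a stated time of 72 h; a lower number here means a stronger inhibitor, a higher number a weaker inhibitor: compound 1 gives 25 nM, whereas compound 2 `CC1CCN(C2CCN(S(=O)(=O)c3cccc(-c4ccc(F)cc4)c3)CC2)CC1` gives 12 nM and compound 3 `CC1CCN(C2CCN(S(=O)(=O)c3cccc(-c4ccccc4)c3)CC2)CC1` gives 2 nM. Compound 4 `CC1CCN(C2CCN(S(=O)(=O)c3cc(Cl)cc(Cl)c3)CC2)CC1` differs from compound 1 by 3,5-dichlorophenyl in place of 3-methylphenyl on a sulfonyl sulfur. The measured steps all change the same methyl of compound 1: a 2.1-fold lower number from compound 1 to compound 2 (0.32 log units; beyond the scatter) and a 13-fold lower number from compound 1 to compound 3 (1.10 log units; beyond the scatter), and the two products are separated by a 6.0-fold lower number from compound 2 to compound 3 (0.78 log units; beyond the scatter). None of these steps swaps that methyl for chlorines, so they bear only loosely on compound 4; both earlier changes of the methyl lowered the number, though with a ring rather than halogens. Compound 4 is therefore expected to give 20 nM, within 6 nM to 60 nM. That amounts to an expected step of a 1.3-fold lower number from compound 1 to compound 4 (0.10 log units; within the scatter).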

Compound 4, half-maximal inhibitory concentration: 3400 nM
Beside the measured number, compound 4's estimate is 170-fold (2.23 log units) below it; measured number above the stated range.
By their numbers in this assay, from the lowest: compound 3; then compound 2; then compound 1; then compound 4.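

Putting 3,5-dichlorophenyl in place of 3-methylphenyl on the sulfonyl sulfur gives a 140-fold higher number from compound 1 to compound 4 (2.13 log units; beyond the scatter) in this assay. The earlier steps at this group all lowered the number, so this place is now shown to move strongly in both directions, and a change that adds only a single heavy atom can cost far more than the phenyl-bearing changes gained. Nothing available accounts for this reversal. The compounds shown leave open whether one chlorine alone would raise the number as far, and how a methoxy group or an amine on that ring would fare.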